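A few compounds are considered here, and "the series" means these few. Any claim that something is new, unique, unknown or untested is made for them only; others in the source may bear on it.

Compound 1 `Cn1cnc2c(N3CCCCC3)nc(-c3ccccc3O)nc21` gives 50.5% in an assay on cells for displacement of a labelled ligand from adenosine receptor A1 (Homo sapiens), read by scintillation counting and radioligand binding, with a stated time of 60 min, tested at 10 uM; on this read-out higher numbers stand for more inhibition at the one concentration tested (going by the name of the read-out) and lower numbers for less inhibition.
Compound 2 `CN1CCN(c2nc(-c3ccc(Cl)cc3)nc3[nH]cnc23)CC1` gives > 80% in this assay, which is a limit of the assay and not a number.
Compound 3 `CN1CCN(c2nc(-c3cccc(Cl)c3)nc3c2ncn3C)CC1` gives 45.7% in this assay.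

Compound 2 thus stands at the limit, (the limit of > 80% in this assay, at which 1 of the 3 values shown sits), and its reading is known only as that limit. The readings of compound 1 and compound 3 lie within the scatter of each other. Compound 4 `CN1CCN(c2nc(-c3ccc(Cl)c(C(F)(F)F)c3)nc3[nH]cnc23)CC1` differs from compound 2 in one place: trifluoromethyl in place of hydrogen on an aromatic carbon. No step between measured compounds is available, so the size of this change cannot be read from any pair shown. The account expects compound 4 to stay in the high region, with no step beyond the scatter in this assay. Compound 4 is estimated at 78%, between 50% and 95%. The expected step is a number at least 2 percentage points lower from compound 2 to compound 4 (that floor lies within the scatter).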

Compound 4, a percentage reported as inhibition, at one concentration (the size of the read-out at that concentration, not a potency): 52.4%
The estimate for compound 4 lay 25.6 percentage points above the measured number; the range from low to high includes it.
By their numbers in this assay, from the lowest: compounds 3, 1 and 4 (each within the scatter of the next). At a limit, above all of these: compound 2.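

Trifluoromethyl in place of hydrogen on this aromatic carbon, ortho to a chloro group, gives the first step that can be sized in this assay: a number at least 27.6 percentage points lower from compound 2 to compound 4 (beyond the scatter). The reading of compound 2 behind this step is a limit and not a number: the limit of > 80% in this assay, at which 1 of the 4 values shown sits. Within the data shown here, the position is therefore not indifferent to what it carries, which the earlier compounds could not show.

The compounds shown leave open whether a smaller group, such as fluoro or methyl, would bring a step of similar size at this position.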